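Replacing Cyano with Fluoro in a Cytotoxicity Screen

A few compounds are considered here, and "the series" means these few. Any claim that something is new, unique, unknown or untested is made for them only; others in the source may bear on it.

Of the compounds shown here, three built on one shared core have been tested in an ADME assay on Vero cells (Chlorocebus sabaeus) for cytotoxicity, read by fluorescence and resazurin assay, with a stated time of 3 days; on this read-out lower numbers stand for higher toxicity in this test and higher numbers for lower toxicity in this test. Compound 1 `CC(=O)C[C@H]1O[C@@H](On2cc(CN3C(=O)/C(=N\Nc4ccc(C#N)cc4)c4ccccc43)nn2)[C@H](OC(C)=O)[C@@H](OC(C)=O)[C@@H]1OC(C)=O` gives 75400 nM in this assay. Compound 2 `CC(=O)C[C@H]1O[C@@H](On2cc(CN3C(=O)/C(=N\Nc4ccc(F)cc4)c4ccccc43)nn2)[C@H](OC(C)=O)[C@@H](OC(C)=O)[C@@H]1OC(C)=O` gives 68700 nM. Compound 3 `CC(=O)C[C@H]1O[C@@H](On2cc(CN3C(=O)/C(=N\Nc4ccc(C#N)cc4)c4ccccc43)nn2)[C@H](OC(C)=O)[C@@H](OC(C)=O)[C@H]1OC(C)=O` gives 75500 nM.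

Compound 2 is related to compound 1 by a single change: fluoro in place of cyano on an aromatic carbon. The measured outcome of that change is a 1.1-fold lower number from compound 1 to compound 2 (0.04 log units; within the scatter), so the two compounds read alike in this assay. Compound 3 and compound 1 share every atom and bond; the outcome there is a 1.0-fold higher number from compound 1 to compound 3 (0.00 log units; within the scatter), and the only thing separating them is the fact that compounds 1 and 3 differ only in the configuration as drawn.

Compound 4 `CC(=O)C[C@H]1O[C@@H](On2cc(CN3C(=O)/C(=N\Nc4ccc(F)cc4)c4ccccc43)nn2)[C@H](OC(C)=O)[C@@H](OC(C)=O)[C@H]1OC(C)=O` awaits measurement. It relates to compound 3 as compound 2 relates to compound 1: fluoro in place of cyano on an aromatic carbon. The place of the change is described in the same words both times, so it is the same change, made on a core that differs from the core of compound 1 only in this way: the two compounds have the same atoms and bonds and differ only in configuration as drawn: 1 of 6 stereo elements differ; a stereocentre at a saturated ring carbon is drawn R in compound 1 and S in compound 3. Because the same change gave a 1.1-fold lower number from compound 1 to compound 2 (0.04 log units; within the scatter) on the core of compound 1, and alongside compound 1 compound 3 gives 75500 nM, the expected step is a 1.1-fold lower number from compound 3 to compound 4 (0.04 log units; within the scatter). Compound 4 is therefore estimated to give 69000 nM in this assay, most likely between 45000 nM and 105000 nM.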

Compound 4, half-maximal cytotoxic concentration: 78600 nM
Estimate against measurement, compound 4: 1.1-fold (0.06 log units) below, within the range that was stated.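

In this assay, fluoro in place of cyano on the core of compound 3 gives a 1.0-fold higher number from compound 3 to compound 4 (0.02 log units; within the scatter), and set beside the same change on the core of compound 1, the two steps agree: the same change on two cores in this assay, a 1.1-fold lower number (0.04 log units; within the scatter) from compound 1 to compound 2 and a 1.0-fold higher number (0.02 log units; within the scatter) from compound 3 to compound 4, 1.1-fold (0.06 log units) apart, within the scatter of two such steps. The drawn stereocentre likewise makes no measurable difference among the fluoro compounds, with a 1.1-fold higher number from compound 2 to compound 4 (0.06 log units; within the scatter), and the comparison is a clean one for this single feature: the fact that compounds 2 and 4 differ only in the configuration as drawn. This shows that the change carries across these two cores only in a limited sense: it leaves the number within the scatter on both, so there is no sizeable effect whose transfer could be tested, and these cores differ at just one stereocentre, which says nothing about a core that differs more widely.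

As far as these compounds go, only cyano and fluoro appear at this aromatic carbon, so it remains open whether an amine or a carboxylic acid there would move the number in this assay beyond the scatter. From the compounds shown here alone, it also remains open whether replacing the acetate groups, which all four compounds carry, would change the reading, or whether fluoro and cyano would stay level on a core with such a replacement.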